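A few compounds are considered here, and "the series" means these few. Any claim that something is new, unique, unknown or untested is made for them only; others in the source may bear on it.

Three ester-bearing bridged amines from one series have been compared for their effect on rat muscle cells. Compound 1 `CN(C)C12CC(OC(=O)CN3CCCCC3)C(C(c3ccccc3)C1)C(c1ccccc1)C2` gives 29300 nM in an ADME assay on L6 cells (Rattus norvegicus) for cytotoxicity; on this read-out lower numbers stand for stronger inhibition and higher numbers for weaker inhibition. Compound 2 `O=C(CN1CCCCC1)OC1CC2(N3CCCC3)CC(c3ccccc3)C1C(c1ccccc1)C2` gives 14200 nM in this assay, and the difference between the two, (pyrrolidin-1-yl in place of dimethylamino on a saturated ring carbon), makes a 2.1-fold lower number from compound 1 to compound 2 (0.31 log units; beyond the scatter). Compound 3 `CN(C)C12CC(OC(=O)CCN3CCCCC3)C(C(c3ccccc3)C1)C(c1ccccc1)C2` gives 25800 nM in this assay; here the chain on the ester differs from compound 1 by (piperidin-1-yl)methyl in place of piperidin-1-yl on a saturated chain carbon bound to a carbonyl carbon, and this makes a 1.1-fold lower number from compound 1 to compound 3 (0.06 log units; within the scatter).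

Compound 4 `O=C(CCN1CCCCC1)OC1CC2(N3CCCC3)CC(c3ccccc3)C1C(c1ccccc1)C2` is not yet measured. It differs from compound 3 by pyrrolidin-1-yl in place of dimethylamino on a saturated ring carbon, the same kind of change as that from compound 1 to compound 2; the surroundings of the place differ only in that the ring atom there bears a ((2-(piperidin-1-yl)ethyl)carbonyl)oxy group rather than a (((piperidin-1-yl)methyl)carbonyl)oxy group. Because a 1.1-fold lower number from compound 1 to compound 3 (0.06 log units; within the scatter) is within the scatter, the two cores are expected to behave alike, so compound 4 is expected to show a 2.1-fold lower number from compound 3 to compound 4 (0.32 log units; beyond the scatter) in this assay, matching the earlier step. Compound 4 is therefore estimated at 12300 nM, most likely between 7000 nM and 22000 nM.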

Compound 4, half-maximal inhibitory concentration: 17800 nM
Beside the measured number, compound 4's estimate is 1.4-fold (0.16 log units) below it; the range from low to high includes it.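

Carried onto the core of compound 3, pyrrolidin-1-yl in place of dimethylamino gives a 1.4-fold lower number from compound 3 to compound 4 (0.16 log units; within the scatter) in this assay, a step that cannot be told from scatter on this core but also does not differ from the earlier one: the same change on two cores in this assay, a 2.1-fold lower number (0.31 log units; beyond the scatter) from compound 1 to compound 2 and a 1.4-fold lower number (0.16 log units; within the scatter) from compound 3 to compound 4, 1.4-fold (0.15 log units) apart, within the scatter of two such steps

The change in the ester chain, (piperidin-1-yl)methyl in place of piperidin-1-yl, gives a 1.3-fold higher number from compound 2 to compound 4 (0.10 log units; within the scatter) and also agrees between the two cores: the same change on two cores in this assay, a 1.1-fold lower number (0.06 log units; within the scatter) from compound 1 to compound 3 and a 1.3-fold higher number (0.10 log units; within the scatter) from compound 2 to compound 4, 1.4-fold (0.15 log units) apart, within the scatter of two such steps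

Going by these compounds alone, these results fit both changes carrying from one core to the other, but they do not establish a fixed size for the ring-carbon step, which lies beyond the scatter on only one of the two cores, and these four compounds say nothing of other cores.

The compounds shown leave open how the step would read with a larger ring amine on that ring carbon, such as piperidin-1-yl or morpholin-4-yl. They also leave open the effect of a longer chain on the ester, or of an amide in place of the ester.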